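A few compounds are considered here, and "the series" means these few. Any claim that something is new, unique, unknown or untested is made for them only; others in the source may bear on it.

Series notes, an ADME assay on liver for metabolic stability, with Liver microsome (Homo sapiens) as the target, read by LC-MS, using microsomes; a higher number here means faster removal of the compound, a lower number slower removal.
Compound 1 `O=C(NCc1cc(Cl)ccc1-n1cnnn1)[C@@H]1C[C@@H]2C[C@@H]2N1C(=O)[C@H](O)Cc1ccccn1` gives 17 mL.min-1.g-1.
Compound 2 `O=C(NCc1cc(Cl)ccc1-n1cnnn1)[C@@H]1C[C@@H]2C[C@@H]2N1C(=O)[C@H](O)c1cccc(Cl)c1` returns > 500 mL.min-1.g-1, which is a limit of this assay and not a number.
Compound 3 `CC(C)(C)OC[C@@H](O)C(=O)N1[C@H](C(=O)NCc2cc(Cl)ccc2-n2cnnn2)C[C@@H]2C[C@@H]21` gives 21 mL.min-1.g-1.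

Compound 3 stands at the higher of the two numbers shown, with compound 1 nearest at a 1.2-fold higher number from compound 1 to compound 3 (0.09 log units; within the scatter), a gap within the scatter; compound 2 contributes only a limit. Compound 4 `O=C(NCc1cc(Cl)ccc1-n1cnnn1)[C@@H]1C[C@@H]2C[C@@H]2N1C(=O)[C@H](O)C1CCCCC1` has not yet been measured. Its change from compound 3 is cyclohexyl in place of (tert-butoxy)methyl on a saturated chain carbon bound to a carbonyl carbon and an oxygen on a saturated carbon, a ring entering where a chain group leaves, on the saturated chain carbon bound to a carbonyl carbon and an oxygen on a saturated carbon. The measured steps at this same position are an at least 23-fold lower number from compound 2 to compound 3 (1.37 log units; beyond the scatter) and an at least 29-fold higher number from compound 1 to compound 2 (1.46 log units; beyond the scatter). In both, compound 2 with 3-chlorophenyl sits at the limit of > 500 mL.min-1.g-1 in this assay, at which 1 of the 3 values shown sits. Compound 1 and compound 3, each carrying a chain group at that carbon, sit far lower. The cyclohexyl entering in compound 4 is not aromatic and is not 3-chlorophenyl, so the precedent is loose; still, a rise beyond the scatter in this assay is expected, smaller than the step to compound 2. Compound 4 is estimated at 90 mL.min-1.g-1, from 30 mL.min-1.g-1 to 300 mL.min-1.g-1. The expected step is a 4.3-fold higher number from compound 3 to compound 4 (0.63 log units; beyond the scatter).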

Compound 4, intrinsic clearance in microsomes: 150 mL.min-1.g-1
Beside the measured number, compound 4's estimate is 1.7-fold (0.22 log units) below it; the measured number falls inside the stated range.
By their numbers in this assay, from the lowest: compounds 1 and 3 (each within the scatter of the next); then compound 4. At a limit, above all of these: compound 2.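

In this assay cyclohexyl, an all-carbon ring bound directly to the saturated chain carbon, gives a clear rise over both groups that reach this carbon through a chain carbon: a 7.1-fold higher number from compound 3 to compound 4 (0.85 log units; beyond the scatter), and an 8.8-fold higher number from compound 1 to compound 4 (0.95 log units; beyond the scatter). The number does not climb as far as it does with 3-chlorophenyl, an at least 3.3-fold lower number from compound 2 to compound 4 (0.52 log units; beyond the scatter), so among the compounds shown a ring bound directly to this carbon raises the number in both cases, yet a non-aromatic ring stops short of the aromatic one. Compound 2 stands at a limit of the assay and not at a number: the limit of > 500 mL.min-1.g-1 in this assay, at which 1 of the 4 values shown sits.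

The compounds shown leave open whether compounds 1 and 3 are set apart from compound 4 by the chain carbon that links their groups to this position or by the nitrogen and oxygen those groups carry. A cyclohexylmethyl group would test the link, and a tetrahydropyranyl or piperidinyl ring in place of cyclohexyl would test the ring atoms.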